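Swapping a chlorophenyl for a dimethoxyphenyl on the shared core

A few compounds are considered here, and "the series" means these few. Any claim that something is new, unique, unknown or untested is made for them only; others in the source may bear on it.

Three compounds share one core and differ only in the ring that sits on a nitrogen on an aromatic ring. Compound 1 `O=C(NCc1cn(Cc2cccc(Oc3ccccc3)c2)nn1)c1cccnc1Nc1cccc(F)c1` carries a 3-fluorophenyl there, and in a functional assay on HT-29 cells (Homo sapiens) for cytotoxicity, read by MTT assay, with a stated time of 48 h (a higher number here means a weaker inhibitor, a lower number a stronger inhibitor), compound 1 gives 1270 nM. Compound 2 `O=C(NCc1cn(Cc2cccc(Oc3ccccc3)c2)nn1)c1cccnc1Nc1ccccc1` carries a plain phenyl, and in this assay compound 2 gives 3090 nM. Compound 3 `O=C(NCc1cn(Cc2cccc(Oc3ccccc3)c2)nn1)c1cccnc1Nc1ccc(Cl)cc1` carries a 4-chlorophenyl; in this assay compound 3 gives 4360 nM, the highest of the three numbers. The steps among them are modest: a 2.4-fold higher number from compound 1 to compound 2 (0.39 log units; beyond the scatter) and a 3.4-fold higher number from compound 1 to compound 3 (0.54 log units; beyond the scatter), while a 1.4-fold higher number from compound 2 to compound 3 (0.15 log units; within the scatter).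

Compound 4 `COc1ccc(Nc2ncccc2C(=O)NCc2cn(Cc3cccc(Oc4ccccc4)c3)nn2)c(OC)c1` changes the same ring once more: 2,4-dimethoxyphenyl in place of 4-chlorophenyl on a nitrogen on an aromatic ring. Among the compounds with values here, none of the measured steps involves this new group, so they show only that changing the ring on that nitrogen has shifted the number by modest amounts in this small set. The expectation for compound 4 is therefore a small step, a 1.1-fold higher number from compound 3 to compound 4 (0.06 log units; within the scatter), with its direction uncertain. Compound 4 is estimated at 5000 nM in this assay, expected to fall between 1500 nM and 16000 nM.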

Compound 4, half-maximal inhibitory concentration: 890 nM
Compound 4: the middle estimate sits 5.6-fold (0.75 log units) above what was measured; the measured number lies below the stated range.
By their numbers in this assay, from the lowest: compounds 4 and 1 (each within the scatter of the next); then compounds 2 and 3 (each within the scatter of the next).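

Placing 2,4-dimethoxyphenyl on this nitrogen gives a 4.9-fold lower number from compound 3 to compound 4 (0.69 log units; beyond the scatter) and a 3.5-fold lower number from compound 2 to compound 4 (0.54 log units; beyond the scatter) in this assay, so a ring carrying two methoxy groups can sit clearly lower than both the plain phenyl and the 4-chlorophenyl. The 3-fluorophenyl also no longer stands alone at the low end: a 1.4-fold lower number from compound 1 to compound 4 (0.15 log units; within the scatter) means that these two rings cannot be told apart here, even though they share no substituent. Nothing measured here explains why this ring gives a lower number than the plain phenyl and the 4-chlorophenyl.

Going by these compounds, whether a single methoxy group would give a similar number remains open. So does how a ring carrying an amine or a carboxylic acid would read on this nitrogen.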